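Taking the Isopropyl Group off the Amide Nitrogen

The compounds below may be only part of what the source reports. "The series", "measured", "known", "first", "only" and "open" are said of these compounds alone.

Among the compounds with values here, in a functional assay (muscle tissue) with Rattus norvegicus as the target (a lower number here means that less compound is needed, a higher number that more compound is needed for the effect), compound 1 (`CC(C)NC(=O)C1=CC(C)(C)Oc2ccc([N+](=O)[O-])cc21`) gives 186 nM, the highest of the three numbers measured so far. Compound 2 (`CC1(C)C=C(C(=O)NC2CC2)c2cc([N+](=O)[O-])ccc2O1`) gives 32.4 nM, and compound 3 (`CC1(C)C=C(C(=O)NCC2CC2)c2cc([N+](=O)[O-])ccc2O1`) gives 6.61 nM. The unmeasured compound 4 (`CC1(C)C=C(C(N)=O)c2cc([N+](=O)[O-])ccc2O1`) has hydrogen in place of isopropyl on an amide-type nitrogen, so that the carbon substituent is lost altogether: hydrogen in place of isopropyl on an amide-type nitrogen.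

Within the data shown here, three measured steps bear on this change. Cyclopropyl in place of isopropyl gave a modest 5.7-fold lower number from compound 1 to compound 2 (0.76 log units; beyond the scatter), cyclopropylmethyl in place of isopropyl gave a large 28-fold lower number from compound 1 to compound 3 (1.45 log units; beyond the scatter), and cyclopropylmethyl in place of cyclopropyl gave a modest 4.9-fold lower number from compound 2 to compound 3 (0.69 log units; beyond the scatter). Each lies beyond the scatter, so the substituent on this nitrogen clearly matters in these compounds. However, every measured compound carries a carbon substituent there, so no step shows the effect of removing it, and the direction remains uncertain. A modest step to a higher number is expected in this assay. The estimated change is a 2.4-fold higher number from compound 1 to compound 4 (0.38 log units; beyond the scatter). The expected value for compound 4 is 450 nM, with an estimated range of 80 nM to 2500 nM.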

Compound 4, half-maximal effective concentration: 363 nM
The estimate for compound 4 lay 1.2-fold (0.09 log units) above the measured number; the measured number falls inside the stated range.
By their numbers in this assay, from the lowest: compound 3; then compound 2; then compounds 1 and 4 (each within the scatter of the next).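

Hydrogen in place of isopropyl on the amide-type nitrogen gave a 2.0-fold higher number from compound 1 to compound 4 (0.29 log units; within the scatter), so in this assay these two compounds cannot be told apart, and having a carbon substituent there does not by itself lower the number. The cyclopropyl and cyclopropylmethyl groups do separate from hydrogen, with hydrogen in their place giving an 11-fold higher number from compound 2 to compound 4 (1.05 log units; beyond the scatter) and a 55-fold higher number from compound 3 to compound 4 (1.74 log units; beyond the scatter), so the low numbers of this small set belong to these two substituents and not to isopropyl. No measurement is available here that would account for this difference between the substituents.

The compounds shown leave open whether the cyclopropyl ring itself matters, as a straight propyl or butyl chain would test against cyclopropylmethyl. They also leave open how a larger cyclobutylmethyl or benzyl group on this nitrogen would compare.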